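From anilino to (4-methoxyphenyl)amino: a step behind a limit

The compounds below may be only part of what the source reports. "The series", "measured", "known", "first", "only" and "open" are said of these compounds alone.

In an ADME assay on A549 cells (Homo sapiens) for cytotoxicity, read by MTT assay, with a stated time of 4 days (a lower number here means a stronger inhibitor, a higher number a weaker inhibitor), compound 1 `COc1cc(C[C@H]2C(=O)OC[C@@H]2Cc2ccc(OC)c(OC)c2)ccc1NC(=O)c1ccccc1` gives > 50000 nM, which is a limit and not a number. Compound 2 `CCC(=O)Nc1ccc(C[C@H]2C(=O)OC[C@@H]2Cc2ccc(OC)c(OC)c2)cc1OC` gives > 50000 nM, also a limit. Compound 3 `COc1cc(C[C@H]2C(=O)OC[C@@H]2Cc2ccc(OC)c(OC)c2)ccc1Nc1ccccc1` gives > 50000 nM, again a limit. So compound 3 stands where the whole set stands: the limit of > 50000 nM in this assay, at which 3 of the 3 values shown sit.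

Compound 4 `COc1ccc(Nc2ccc(C[C@H]3C(=O)OC[C@@H]3Cc3ccc(OC)c(OC)c3)cc2OC)cc1` carries methoxy in place of hydrogen on an aromatic carbon of the phenyl of compound 3, making it 4-methoxyphenyl (methoxy in place of hydrogen on an aromatic carbon). The measured steps nearest this change, a step that the two limits leave unreadable from compound 1 to compound 3 and a step that the two limits leave unreadable from compound 2 to compound 3, have no readable size, and none of them tests this methoxy. No step beyond the scatter is therefore expected, and the estimated move is a number no higher from compound 3 to compound 4 (the limit leaves the size open). For compound 4 the expected value is 50000 nM, with an estimated range of 25000 nM to 100000 nM.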

Compound 4, half-maximal inhibitory concentration: > 50000 nM
Compound 4: only a limit was reported (the forecaster's own chance of this, stated with the estimate: 85%); the middle value sits exactly at the limit.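

No step can be read between compound 4 and compound 1, compound 2 or compound 3, since each gives only a limit: the limit of > 50000 nM in this assay, at which 4 of the 4 values shown sit.

The compounds shown leave open how far any of the four lies past that limit, and so whether the methoxy changes anything.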